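Swapping the benzyl arm on the shared core from dimethoxy to fluoro

This account rests on a few compounds, and the source may have more. Where it says the series, first, only, none or still open, it means among the compounds named here.

Compound 3 `COc1ccc(CNc2nc3cc(N)cc(N)c3nc2-c2ccccc2)cc1OC` carries a benzylamine arm on the shared core. In a functional assay on RXF 393 cells (Homo sapiens) for inhibition, read by sulforhodamine B assay, with a stated time of 48 h (on this read-out lower numbers stand for stronger inhibition of growth and higher numbers for weaker inhibition of growth), compound 3 gives < 100000 nM, which is a limit of the assay rather than a number. Compound 1 `Nc1cc(N)c2nc(-c3ccccc3)c(Sc3ccc(F)cc3)nc2c1` likewise yields only a limit, < 100000 nM, in this assay. Compound 2 `Nc1cc(N)c2nc(-c3ccccc3)c(Sc3ccc(Cl)c(Cl)c3)nc2c1` gives 26900 nM in this assay. The step that the limit leaves unreadable from compound 1 to compound 2 thus cannot be sized, and it concerns an arm on a sulfur rather than the nitrogen-linked arm of compound 3. Compound 4 `Nc1cc(N)c2nc(-c3ccccc3)c(NCc3ccc(F)cc3)nc2c1` arises through (4-fluorophenyl in place of 3,4-dimethoxyphenyl on a saturated chain carbon bound to a nitrogen on an aromatic ring). Going by the values given here, no measured step bears directly on this exchange, and the limit of < 100000 nM in this assay, at which 2 of the 3 values shown sit, shows how much of the set sits at the edge of what this assay reports. The estimated step that the limit leaves unreadable from compound 3 to compound 4 is expected to be small and without a trustworthy direction. For compound 4 the estimate is 60000 nM, with a range from 15000 nM to 100000 nM.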

Compound 4, concentration for total growth inhibition: 26900 nM
Beside the measured number, compound 4's estimate is 2.2-fold (0.35 log units) above it; measured number inside the range.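

Going by these compounds alone, compound 4 gives the first readable number for a nitrogen-linked arm on the shared core in this assay, where compound 3 offered only a limit. Exchanging the sulfur-linked arm for the nitrogen-linked one shows no change at the digits printed from compound 2 to compound 4 (within the scatter), so this pair does not separate (4-fluorobenzyl)amino from (3,4-dichlorophenyl)sulfanyl. The steps to compound 4 from compound 3 and from compound 1 cannot be read, because each starts from a limit: the limit of < 100000 nM in this assay, at which 2 of the 4 values shown sit.

On these data alone, whether 4-fluorophenyl truly differs from 3,4-dimethoxyphenyl on this arm stays open. Also open, as far as these compounds go, is what a carboxylic acid or an amine in place of 4-fluorophenyl would give.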